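Furan-2-yl Gives Way to Ethynyl

The compounds below may be only part of what the source reports. "The series", "measured", "known", "first", "only" and "open" are said of these compounds alone.

In a functional assay on K562 cells (Homo sapiens), read by MTT assay, with a stated time of 72 h (on this read-out higher numbers stand for weaker inhibition and lower numbers for stronger inhibition), compound 3 (`CNc1ncnc2c1c(-c1ccco1)cn2[C@@H]1O[C@H](CO)[C@@H](O)[C@H]1O`) gives 15100 nM. Compound 1 (`COc1ncnc2c1c(-c1cc3ccccc3o1)cn2[C@@H]1O[C@H](CO)[C@@H](O)[C@H]1O`) gives 13100 nM, a number within the usual scatter of that of compound 3. Compound 2 (`CSc1ncnc2c1c(-c1ccccc1)cn2[C@@H]1O[C@H](CO)[C@@H](O)[C@H]1O`) reports only a limit, > 20000 nM. Compound 4 (`C#Cc1cn([C@@H]2O[C@H](CO)[C@@H](O)[C@H]2O)c2ncnc(NC)c12`) carries ethynyl in place of the furan-2-yl of compound 3, on an aromatic carbon (ethynyl in place of furan-2-yl on an aromatic carbon). Going by the values given here, no two measured compounds differ in one place alone, so no direct comparison sizes this change. In this assay, a small move toward a lower number is expected, hardly beyond the scatter. The expected step is a 1.7-fold lower number from compound 3 to compound 4 (0.22 log units; within the scatter). For compound 4, the estimated value is 9000 nM, with an expected range of 1200 nM to 20000 nM.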

Compound 4, half-maximal inhibitory concentration: 1380 nM
Compound 4: the middle estimate sits 6.5-fold (0.81 log units) above what was measured; the measured number falls inside the stated range.
By their numbers in this assay, from the lowest: compound 4; then compounds 1 and 3 (each within the scatter of the next). At a limit, above all of these: compound 2.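

Replacing furan-2-yl with ethynyl on this aromatic carbon gives an 11-fold lower number from compound 3 to compound 4 (1.04 log units; beyond the scatter) in this assay and so shows that the group at this position can strongly change the read-out. A ring is not needed here for stronger inhibition, since ethynyl has no ring and only 2 heavy atoms against the 5 of furan-2-yl. No measurement shown accounts for the size of this step.

On these data alone, whether a nitrile or a propyl chain at this position would give a similar step remains open. So does whether ethynyl would act alike on the core of compound 1.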